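The source may report more compounds than this note shows. Statements on the series, on what has been measured and on what is new or still open speak of the compounds shown alone.

Measured compounds:
compound 1 `CCOC(=O)C1=C(C)N/C(=C/c2cc(C)n(-c3cccc(C(F)(F)F)c3)c2C)C1=O` — 100000 nM
compound 2 `CCOC(=O)C1=C(C)N/C(=C/c2cc(C)n(-c3ccc(F)cc3F)c2C)C1=O` — 14000 nM
compound 3 `CCOC(=O)C1=C(C)N/C(=C/c2cc(C)n(-c3ccc([S+](C)[O-])cc3)c2C)C1=O` — 220000 nM

In an ADME assay on L6 cells (Rattus norvegicus) for cytotoxicity, read by resazurin assay, with a stated time of 72 h (on this read-out higher numbers stand for an effect only at larger amounts of compound and lower numbers for an effect already at smaller amounts), compound 3 gives the highest of the three numbers; the step from compound 1 to compound 3 was a 2.2-fold higher number from compound 1 to compound 3 (0.34 log units; beyond the scatter), and from compound 2 to compound 3 it was a 16-fold higher number from compound 2 to compound 3 (1.20 log units; beyond the scatter). Compound 4 `CCOC(=O)C1=C(C)N/C(=C/c2cc(C)n(Cc3ccccc3)c2C)C1=O` carries a group of 7 heavy atoms (7 carbon; one six-membered aromatic ring of carbon only) in place of a group of 9 heavy atoms (7 carbon, 1 oxygen, 1 sulfur; one six-membered aromatic ring of carbon only), on an aromatic nitrogen. Going by the values given here, no measured step puts a benzyl there, so the nearest guidance is that every change at that aromatic nitrogen moved the number by a 7.1-fold lower number from compound 1 to compound 2 (0.85 log units; beyond the scatter) up to a 16-fold higher number from compound 2 to compound 3 (1.20 log units; beyond the scatter). A modest step downward from compound 3 in this assay is therefore expected, bringing compound 4 toward the numbers of compound 1 and compound 2: an estimated 3.7-fold lower number from compound 3 to compound 4 (0.56 log units; beyond the scatter), giving compound 4 an expected 60000 nM within a range of 15000 nM to 250000 nM.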

Compound 4, half-maximal effective concentration: 50000 nM
Beside the measured number, compound 4's estimate is 1.2-fold (0.08 log units) above it; low and high end bracket the measured number.
By their numbers in this assay, from the lowest: compound 2; then compounds 4 and 1 (each within the scatter of the next); then compound 3.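

In this assay benzyl on the aromatic nitrogen, the only group shown with a carbon between its ring and that nitrogen, falls inside the span set by the directly attached rings: a 4.4-fold lower number from compound 3 to compound 4 (0.64 log units; beyond the scatter) and a 3.6-fold higher number from compound 2 to compound 4 (0.55 log units; beyond the scatter) are both beyond the scatter, while a 2.0-fold lower number from compound 1 to compound 4 (0.30 log units; within the scatter) lies within it. Among these four compounds, then, the ring need not sit directly on the nitrogen for the number to stay within that span. Nothing given here accounts for these steps. Going by these compounds, whether an amine or a carboxylic acid on the benzyl ring, or a longer chain in place of benzyl, would stay inside that span remains open.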